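The source may hold more compounds than are shown below. What is called first, only, known or untested is meant among the compounds shown, and "the series" means these compounds.

Among the measured compounds shown here, in a functional assay on A-375 cells (Homo sapiens) for antiproliferative activity, read by MTT assay, with a stated time of 72 h (a lower number here means a stronger inhibitor, a higher number a weaker inhibitor), compound 1 (`COc1ncc(-c2ccc3c(c2)N(c2ccc(C)cc2)C(=O)CO3)cc1NS(=O)(=O)c1ccc(F)cc1`) gives 12900 nM and compound 2 (`COc1ncc(-c2ccc3c(c2)N(C2CC2)C(=O)CO3)cc1NS(=O)(=O)c1ccc(F)cc1`) gives 23900 nM as the only two numbers so far. These two values lie within the scatter of each other, so compound 2 holds no separate place on this scale. Compound 3 (`COc1ccc(N2C(=O)COc3ccc(-c4cnc(OC)c(NS(=O)(=O)c5ccc(F)cc5)c4)cc32)cc1`) has 4-methoxyphenyl in place of cyclopropyl on an amide-type nitrogen in a ring and remains unmeasured. For the measured compounds named here, only one measured step bears on this change, the exchange of 4-methylphenyl for cyclopropyl on that same nitrogen (a 1.9-fold higher number from compound 1 to compound 2 (0.27 log units; within the scatter)) and it is small. Going from cyclopropyl back to a substituted phenyl, a slight move toward a lower number is expected in this assay and nothing beyond the scatter. The expected change (a 1.7-fold lower number from compound 2 to compound 3 (0.23 log units; within the scatter)) is therefore modest. Compound 3 is estimated at 14000 nM with an expected range from 6000 nM to 30000 nM in this read-out.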

Compound 3, half-maximal inhibitory concentration: 18400 nM
For compound 3 the middle estimate is 1.3-fold (0.12 log units) below the measured one; the range from low to high includes it.
By their numbers in this assay, from the lowest: compounds 1, 3 and 2 (each within the scatter of the next).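

On the amide-type nitrogen in a ring, in this assay, 4-methoxyphenyl in place of cyclopropyl gives a 1.3-fold lower number from compound 2 to compound 3 (0.11 log units; within the scatter), so a substituent with more heavy atoms, an aromatic ring and a hydrogen-bond acceptor stays within the scatter of the three-membered ring. On the aromatic substituent itself, methoxy in place of methyl on an aromatic carbon gives a 1.4-fold higher number from compound 1 to compound 3 (0.15 log units; within the scatter), which is also within the scatter, so this series now shows two different kinds of change at this place with neither step resolved in this assay. No available data offer an explanation for these results.

From the compounds shown here alone, whether an aminoethyl chain or a carboxylic acid on this nitrogen would give a step beyond the scatter remains open. All three compounds share the rest of the core, so the response to changes elsewhere on it is also unknown.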